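Will compound 4 stay at the limit?

The compounds below may be only part of what the source reports. "The series", "measured", "known", "first", "only" and "open" are said of these compounds alone.

Measured compounds in an ADME assay on BJ cells (Homo sapiens) for cytotoxicity, with a stated time of 72 h; a higher number here means that more compound is needed for the effect, a lower number that less compound is needed
Compound 1 (`Cc1cc(NC(=O)Nc2ccc(N(C)C)cc2)c2ccccc2n1`) gives > 25000 nM as a limit
Compound 2 (`Cc1cc(NC(=O)Nc2ccc(C(N)=O)cc2)c2ccccc2n1`) gives > 25000 nM as a limit
Compound 3 (`Cc1cc(NC(=O)Nc2ncccc2C)c2ccccc2n1`) gives > 25000 nM as a limit

Compound 3 offers no exact number as a starting point, since its value of > 25000 nM is a limit. The same holds across the whole set, summed up by the limit of > 25000 nM in this assay, at which 3 of the 3 values shown sit, with no exact value yet in hand.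

Compound 4 (`Cc1cc(NC(=O)Nc2ccc(N)cc2)c2ccccc2n1`) has not been measured. It differs from compound 3 on an amide-type nitrogen, where 4-aminophenyl stands in place of 3-methylpyridin-2-yl (4-aminophenyl in place of 3-methylpyridin-2-yl on an amide-type nitrogen).

Going by the values given here, only one measured step is available for comparison. It puts carbamoyl in place of dimethylamino on an aromatic carbon and gives a step that the two limits leave unreadable from compound 1 to compound 2 with no size to carry over. The expectation therefore rests on compound 3 with its limit of > 25000 nM and no step beyond the scatter is expected in this assay in either direction.

The expected step is a number no higher from compound 3 to compound 4 (the limit leaves the size open) and its size is only an estimate. For compound 4 the estimated value is 25000 nM with an expected range from 12000 nM to 40000 nM and a report of only a limit is the likeliest outcome.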

Compound 4, half-maximal effective concentration: > 25000 nM
Compound 4 was reported as a limit; the forecaster's own chance of this, stated with the estimate: 75%; the middle value sits exactly at the limit.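

No step from compound 1, compound 2 or compound 3 to compound 4 can be read, as all four compounds stand at one shared limit: the limit of > 25000 nM in this assay, at which 4 of the 4 values shown sit.

The compounds shown leave open what exact concentration any of them needs for the effect, and so whether the groups that differ among them change the result in this assay at all.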